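A few compounds are considered here, and "the series" means these few. Any claim that something is new, unique, unknown or untested is made for them only; others in the source may bear on it.

Compound 1 `Cc1ccc(CSc2nc3nc(C)cc(Nc4cc(-c5ccccc5)[nH]n4)n3n2)cc1` was tested in a functional assay on MCF7 cells (Homo sapiens) for inhibition, read by MTT assay, with a stated time of 72 h (on this read-out higher numbers stand for weaker inhibition and lower numbers for stronger inhibition), where compound 1 gives 7290 nM. Of the two compounds measured in this assay, compound 1 carries the higher of the two numbers. The other, compound 2 `Cc1cc(Nc2ccn(Cc3nc(C)c4ccccc4n3)n2)n2nc(SCc3ccc(Br)cc3)nc2n1`, gives 1430 nM in this assay, and the gap between the two values lies beyond the usual scatter of the method. For the measured compounds named here, no single-point step between measured compounds is available, since compound 1 and compound 2 differ in more than one place, so neither value can be traced to one structural change.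

Compound 3 `COc1ccc(CSc2nc3nc(C)cc(Nc4cc(-c5ccccc5)[nH]n4)n3n2)cc1` has not yet been measured. It is set apart from compound 1 by one change: methoxy in place of methyl on an aromatic carbon. Compound 3 otherwise keeps the shared core of compound 1 unchanged.

Going by the values given here, nothing among the measured pairs speaks directly to this change, so the step from compound 1 to compound 3 is expected to be small, a 1.0-fold lower number from compound 1 to compound 3 (0.02 log units; within the scatter), with no clear direction and probably not beyond the scatter. On that basis compound 3 is estimated to give 7000 nM in this assay, with a range from 3000 nM to 16000 nM.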

Compound 3, half-maximal inhibitory concentration: 4020 nM
Compound 3: the middle estimate sits 1.7-fold (0.24 log units) above what was measured, and the stated range covers the measured number.
By their numbers in this assay, from the lowest: compound 2; then compounds 3 and 1 (each within the scatter of the next).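

In this assay, for the compounds shown here, the change from 4-methylbenzyl to 4-methoxybenzyl gives the first step in this set that can be traced to a single place, a 1.8-fold lower number from compound 1 to compound 3 (0.26 log units; within the scatter). It shows that, with the rest of compound 1 held fixed, this position accepts methoxy in place of methyl, with its added oxygen and hydrogen-bond acceptor, without a shift that can be told from the usual scatter of the method. No independent measurement accompanies this step to explain the small difference, so the data give no account of why the two compounds read so closely.

What the compounds shown leave open is whether a different group on this aromatic carbon, such as an amine, a carboxylic acid or a longer chain like ethoxy, would move the number beyond the scatter. Also open, from the compounds shown here alone, is whether methoxy in place of methyl would give a similar step on a compound built like compound 2, which differs from compound 1 in more than one place and so cannot answer this.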